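Expected step from compound 1 to compound 4

The compounds below may be only part of what the source reports. "The series", "measured", "known", "first", "only" and "open" are said of these compounds alone.

Among the measured compounds shown here, in an ADME assay on L02 cells (Homo sapiens) for cytotoxicity, read by MTT assay, with a stated time of 72 h (on this read-out lower numbers stand for stronger inhibition and higher numbers for weaker inhibition), compound 1 `O=C(O)CCC(=O)OCCCCCCSc1ccc([N+](=O)[O-])c2nonc12` gives 1890 nM, the lowest number of the three measured so far. Compound 3 `COc1ccccc1NC(=O)CCC(=O)OCCCCCCSc1ccc([N+](=O)[O-])c2nonc12` gives 4490 nM and compound 2 `Cc1ccccc1NC(=O)CCC(=O)OCCCCCCSc1ccc([N+](=O)[O-])c2nonc12` gives 9490 nM, and both lie above compound 1 by more than the scatter.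

Compound 4 `O=C(CCC(=O)OCCCCCCSc1ccc([N+](=O)[O-])c2nonc12)Nc1cccc(Cl)c1` is not yet measured. Its change from compound 1 is (3-chlorophenyl)amino in place of hydroxy on a carbonyl carbon.

Two measured steps replace the same hydroxy with a substituted phenylamino group: a 5.0-fold higher number from compound 1 to compound 2 (0.70 log units; beyond the scatter) and a 2.4-fold higher number from compound 1 to compound 3 (0.38 log units; beyond the scatter). Both are modest, both go upward, and both lie beyond the scatter. The step between those two products, a 2.1-fold lower number from compound 2 to compound 3 (0.33 log units; beyond the scatter), shows that the substituent on the aromatic ring also shifts the number, so the outcome is not fixed by the new linkage alone. For the measured compounds named here, no measured compound carries a (3-chlorophenyl)amino group, and the size of the step therefore remains uncertain.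

A modest upward step of similar size is expected, with a number higher than that of compound 1. The expected step is a 3.2-fold higher number from compound 1 to compound 4 (0.50 log units; beyond the scatter). For compound 4 the estimated value is 6000 nM, with an expected range of 2500 nM to 14000 nM.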

Compound 4, half-maximal inhibitory concentration: 6930 nM
For compound 4 the middle estimate is 1.2-fold (0.06 log units) below the measured one; the measured number falls inside the stated range.
By their numbers in this assay, from the lowest: compound 1; then compounds 3, 4 and 2 (each within the scatter of the next, the first and the last beyond it).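

In this assay, the change to (3-chlorophenyl)amino on the carbonyl carbon gives a 3.7-fold higher number from compound 1 to compound 4 (0.56 log units; beyond the scatter), so all three substituted phenylamino compounds shown now stand above compound 1 by more than the scatter, with none going against this, and a chlorine-bearing ring joins the methyl- and methoxy-bearing rings on that side. Although compounds 2 and 3 are separated by a 2.1-fold lower number from compound 2 to compound 3 (0.33 log units; beyond the scatter), compound 4 cannot be told apart from either, as a 1.5-fold higher number from compound 3 to compound 4 (0.19 log units; within the scatter) and a 1.4-fold lower number from compound 2 to compound 4 (0.14 log units; within the scatter) both lie within the scatter, which means that the 3-chlorophenyl group gives no separate reading against the 2-methoxyphenyl or the 2-methylphenyl group. Nothing on hand accounts for the upward step from the carboxy compound to the (3-chlorophenyl)carbamoyl compound.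

The ring substituent and its place on the ring change together across compounds 2, 3 and 4, so a (2-chlorophenyl)amino or an unsubstituted phenylamino group would be needed to read either one alone. On these data alone, it also remains open whether the upward step needs an aromatic ring at all, a question that a morpholine amide or a simple methyl ester at the same carbonyl carbon would address.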